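The compounds below may be only part of what the source reports. "The series", "measured", "known", "first", "only" and "open" are said of these compounds alone.

Measured compounds, cytotoxicity on the shared core:

Compound 1 `O=C(COc1cccc2ccccc12)N/N=C/c1ccc(O)cc1`: in an ADME assay on MT4 cells (Homo sapiens) for cytotoxicity, read by MTT assay, with a stated time of 4 days (a lower number here means that less compound is tolerated, a higher number that more compound is tolerated), compound 1 gives 26.5 ug/mL.
Compound 2 `O=C(COc1cccc2ccccc12)N/N=C/c1cccc([N+](=O)[O-])c1`: in this assay compound 2 gives 12.1 ug/mL.
Compound 3 `COc1ccc(/C=N/NC(=O)COc2cccc3ccccc23)cc1OC`: in this assay compound 3 gives 14.7 ug/mL.

Compound 1 carries the highest number of the three. Its nearest neighbour is compound 3, whose number sits within the scatter of that of compound 1, so no order between these two can be read from the values. Compound 2 lies further off, beyond the scatter, so compound 2 is tolerated less than compound 1 on these numbers. Nothing beyond these three points is known about how changes on the aryl group move the read-out.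

Compound 4 `O=C(COc1cccc2ccccc12)N/N=C/c1ccccc1O` has not been measured. It differs from compound 1 in one place: 2-hydroxyphenyl in place of 4-hydroxyphenyl on a carbon with a double bond to nitrogen. The two compounds hold the same atoms joined differently, so the step is a shift of one group on the same ring. Among the measured compounds shown here, no measured pair shows such a shift, and there is nothing in the three values to say which way it should move the number. The expectation is a step of a 1.2-fold lower number from compound 1 to compound 4 (0.08 log units; within the scatter), that is, none beyond the scatter, with no direction favoured. Compound 4 is therefore estimated at 22 ug/mL, with a range from 11 ug/mL to 44 ug/mL.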

Compound 4, half-maximal cytotoxic concentration: 5.19 ug/mL
Estimate against measurement, compound 4: 4.2-fold (0.63 log units) above; measured number outside the range, below it.
By their numbers in this assay, from the lowest: compound 4; then compounds 2, 3 and 1 (each within the scatter of the next, the first and the last beyond it).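

In this assay, 2-hydroxyphenyl in place of 4-hydroxyphenyl on a carbon with a double bond to nitrogen gives a 5.1-fold lower number from compound 1 to compound 4 (0.71 log units; beyond the scatter), a step beyond the scatter, so less compound is tolerated after the change. Among the compounds shown here, this is the first single-place step, and it shows that the read-out responds to where the hydroxyl stands on this ring, even though the two compounds hold the same atoms and the counts of heavy atoms, donors and acceptors stay the same. Nothing measured on these compounds speaks to what lies behind this step.

The step is one pair on one core, so it sets no rule for the series, and it cannot be said whether an amine or a methoxy group would respond to the same shift on the ring as the hydroxyl does here. From the compounds shown here alone, how plain phenyl, without any hydroxyl, would stand against compound 1 and compound 4 also remains open, as does whether a longer chain in place of the link to the shared core would keep this difference.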